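Removing a Methoxy Group: An Expected Loss in Inhibition

This account rests on a few compounds, and the source may have more. Where it says the series, first, only, none or still open, it means among the compounds named here.

Compound 1 `COc1cc(/C=C2\SC(=O)NC2=O)ccc1OCN1C(=O)c2ccccc2C1=O`: 35100 nM
Compound 2 `O=C1NC(=O)/C(=C/c2ccccc2OCN2C(=O)c3ccccc3C2=O)S1`: > 100000 nM

For the measured compounds named here, in an assay on isolated protein for inhibition of Alpha glucosidase (Homo sapiens), read by spectrophotometry, with stated times of 15 min and 30 min (a lower number here means a stronger inhibitor, a higher number a weaker inhibitor), compound 1 gives 35100 nM, the only numerical value in the set. Compound 2 reaches only a limit of the assay in this assay, > 100000 nM, so it is not a number but (the limit of > 100000 nM in this assay, at which 1 of the 2 values shown sits). Compound 1 therefore stands as the sole measured point, with the other value telling nothing beyond that limit.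

Compound 3 `O=C1NC(=O)/C(=C/c2ccc(OCN3C(=O)c4ccccc4C3=O)cc2)S1` is not yet measured. It differs from compound 1 by hydrogen in place of methoxy on an aromatic carbon. Going by the values given here, no measured pair shows this same change, so the size of the step is open. Among the compounds with values here, a small loss in this assay is expected, of the order of a 1.6-fold higher number from compound 1 to compound 3 (0.20 log units; within the scatter), since the one number available is already weak. Compound 3 is therefore estimated at 55000 nM, within 20000 nM to 150000 nM.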

Compound 3, half-maximal inhibitory concentration: 25600 nM
Estimate against measurement, compound 3: 2.1-fold (0.33 log units) above, and the stated range covers the measured number.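

In this assay, hydrogen in place of methoxy on an aromatic carbon gives a 1.4-fold lower number from compound 1 to compound 3 (0.14 log units; within the scatter). For the compounds shown here, the methoxy group, ortho to a large group and meta to a group of 8 heavy atoms, can therefore be replaced by hydrogen while the two compounds stay within the scatter of each other, which no earlier compound could show, as there was no measured step at this position until now. Nothing among the data shown accounts for this step.

Compound 2 gives only a limit of the assay, > 100000 nM, and so offers no number to set against the others. Going by these compounds, whether a different group on this same aromatic carbon, such as an amine, a fluorine atom or a longer chain like ethoxy, would move the number beyond the scatter remains open.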